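The source may report more compounds than this note shows. Statements on the series, on what has been measured and on what is new or still open speak of the compounds shown alone.

Measured compounds:
Compound 1 `O=C(Nc1cc(C(F)(F)F)cc(C(F)(F)F)c1)C1CCc2ccccc2N1C(=O)c1ccccc1Cl` — 4700 nM
Compound 2 `CC(=O)N1c2ccccc2CCC1C(=O)Nc1ccccc1O` — 50700 nM
Compound 3 `O=C(Nc1ccccc1O)C1CCc2ccccc2N1C(=O)c1ccccc1Cl` — 44200 nM

In a functional assay on ACHN cells (Homo sapiens) for cytotoxicity, read by sulforhodamine B assay, with a stated time of 72 h (on this read-out higher numbers stand for weaker inhibition of growth and lower numbers for stronger inhibition of growth), compound 3 sits at the second highest of the three numbers. Its nearest neighbour is compound 2, with the change a 1.1-fold lower number from compound 2 to compound 3 (0.06 log units; within the scatter), so the two cannot be told apart. Compound 1, which differs from compound 3 at the amide-bearing aryl group, gives a much lower number, and that gap lies beyond the scatter.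

Compound 4 `O=C(Nc1ccccc1O)C1CCc2ccccc2N1C(=O)c1ccc(Cl)cc1` differs from compound 3 by 4-chlorophenyl in place of 2-chlorophenyl on a carbonyl carbon. Among the compounds with values here, no measured pair shows this change: the only step at the same carbonyl carbon, from compound 2 to compound 3, swaps a methyl for the 2-chlorophenyl group and stays within the scatter, and nothing shows how moving the chlorine around the ring would act. In the absence of a bearing step, the number for compound 4 is expected to stay close to that of compound 3, with no step beyond the scatter: a 1.0-fold lower number from compound 3 to compound 4 (0.00 log units; within the scatter). Compound 4 is therefore estimated at 44000 nM, ranging from 15000 nM to 130000 nM.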

Compound 4, concentration for 50% growth inhibition: 19600 nM
Compound 4: middle estimate off by 2.2-fold (0.35 log units), on the high side; measured number inside the range.
By their numbers in this assay, from the lowest: compound 1; then compound 4; then compounds 3 and 2 (each within the scatter of the next).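

In this assay, the place of the chlorine on the ring turns out to count at this carbonyl carbon, whose other neighbour is an amide-type nitrogen in a ring: 4-chlorophenyl in place of 2-chlorophenyl gives a 2.3-fold lower number from compound 3 to compound 4 (0.35 log units; beyond the scatter), a modest step. The earlier swap of methyl for 2-chlorophenyl stayed within the scatter, whereas 4-chlorophenyl in place of methyl gives a 2.6-fold lower number from compound 2 to compound 4 (0.41 log units; beyond the scatter), so a change at this carbon can move the number beyond the scatter. Nothing available explains why the two chlorophenyl groups differ.

As far as these compounds go, whether the same chlorine shift would carry over to the core of compound 1, with its different amide aryl group, remains open. So does the effect of an unsubstituted phenyl, a methoxyphenyl or a carboxylic acid-bearing phenyl on this carbonyl carbon.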